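The source may report more compounds than this note shows. Statements on the series, on what has been measured and on what is new or still open speak of the compounds shown alone.

Compound 3 `NC(=O)c1c(NC(=O)c2ccccc2Cl)sc2c1CCN(C(=O)Nc1ccccc1Cl)C2` stands at the lowest of the three numbers in a functional assay on HL-60 cells (Homo sapiens) for antiproliferative activity, with a stated time of 24 h (on this read-out lower numbers stand for stronger inhibition and higher numbers for weaker inhibition), at 12500 nM, though within the scatter of both others: compound 1 `NC(=O)c1c(NC(=O)c2ccccc2Cl)sc2c1CCNC2` gives 18600 nM and compound 2 `NC(=O)c1c(NC(=O)c2ccccc2Cl)sc2c1CCN(Cc1ccc(Cl)cc1)C2` gives 22500 nM. The steps of a 1.5-fold lower number from compound 1 to compound 3 (0.17 log units; within the scatter) and a 1.8-fold lower number from compound 2 to compound 3 (0.26 log units; within the scatter) stay within the scatter, as does a 1.2-fold higher number from compound 1 to compound 2 (0.08 log units; within the scatter). Compound 4 `NC(=O)c1c(NC(=O)c2ccccc2Cl)sc2c1CCN(C(=O)Nc1c(Cl)cccc1Cl)C2` differs from compound 3 by chloro in place of hydrogen on an aromatic carbon. Going by the values given here, no measured step touches the (2-chlorophenyl)carbamoyl group; all three concern substituents on the amine nitrogen in the ring, and all are small, so they offer no direct guide. Since every step seen in this assay has stayed within the scatter, compound 4 is expected to show no change at the digits printed from compound 3 to compound 4 (within the scatter), no step beyond the scatter. The estimate for compound 4 is 12500 nM, ranging from 5000 nM to 31000 nM.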

Compound 4, half-maximal inhibitory concentration: 17700 nM
Compound 4: the middle estimate sits 1.4-fold (0.15 log units) below what was measured, and the stated range covers the measured number.
By their numbers in this assay, from the lowest: compounds 3, 4, 1 and 2 (each within the scatter of the next).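

In this assay, going by these compounds alone, chloro in place of hydrogen on an aromatic carbon, ortho to a large group, gives the first measured step on the aromatic ring of the carbamoyl group, and that step stays within the scatter (a 1.4-fold higher number from compound 3 to compound 4 (0.15 log units; within the scatter)). The (2,6-dichlorophenyl)carbamoyl group also stays within the scatter of the other two substituents on the amine nitrogen (a 1.3-fold lower number from compound 2 to compound 4 (0.10 log units; within the scatter); a 1.1-fold lower number from compound 1 to compound 4 (0.02 log units; within the scatter)). No evidence is available that would account for these results.

On these data alone, whether an amine or a carboxylic acid on that aromatic carbon, or a longer chain on the amine nitrogen, would give a step beyond the scatter remains open.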